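Swapping Isopropyl for Trifluoromethoxy: an Expected Small Shift

A few compounds are considered here, and "the series" means these few. Any claim that something is new, unique, unknown or untested is made for them only; others in the source may bear on it.

Measured compounds:
Compound 1 `CC1CCN(C2CCN(S(=O)(=O)c3cccc(Br)c3)CC2)CC1` gives 3.2 nM in a functional assay on DLD-1 cells (Homo sapiens) for antiproliferative activity, read by CellTiter-Glo, with a stated time of 72 h; a lower number here means a stronger inhibitor, a higher number a weaker inhibitor.
Compound 2 `CC1CCN(C2CCN(S(=O)(=O)c3ccc(C(C)C)cc3)CC2)CC1` gives 685 nM in this assay.
Compound 3 `CC1CCN(C2CCN(S(=O)(=O)c3cccnc3F)CC2)CC1` reaches only the assay limit, > 5000 nM, in this assay.

Compound 2 stands at the highest of the two numbers; its nearest neighbour is compound 1, and the gap between them lies well beyond the usual scatter. Compound 4 `CC1CCN(C2CCN(S(=O)(=O)c3ccc(OC(F)(F)F)cc3)CC2)CC1` differs from compound 2 by trifluoromethoxy in place of isopropyl on an aromatic carbon. Among the compounds with values here, the only measured step, an at least 1500-fold higher number from compound 1 to compound 3 (3.19 log units; beyond the scatter), replaces the whole ring and is marked by a limit (the limit of > 5000 nM in this assay, at which 1 of the 3 values shown sits), so it bears only loosely on a change of a single group on the carbon ring. Within the data shown here, no measured step tells the direction here, so an expected shift within or just beyond the scatter, in either direction, is the reasonable outcome. Compound 4 is estimated at 1000 nM, between 250 nM and 4000 nM, an expected step of a 1.5-fold higher number from compound 2 to compound 4 (0.16 log units; within the scatter).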

Compound 4, half-maximal inhibitory concentration: 16 nM
For compound 4 the middle estimate is 63-fold (1.80 log units) above the measured one; measured number outside the range, below it.
By their numbers in this assay, from the lowest: compound 1; then compound 4; then compound 2. At a limit, above all of these: compound 3.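

In this assay, the group on the aromatic carbon para to a large group proves decisive: trifluoromethoxy in place of isopropyl gives a 43-fold lower number from compound 2 to compound 4 (1.63 log units; beyond the scatter). Unlike the earlier replacement of the whole ring, this step changes one group on an unchanged carbon ring, so it shows that this position alone can move the number by a large margin. Nothing in the data shown accounts for the size of this step. On these data alone, it remains open how an amine, a carboxylic acid or a longer chain at this position would read in this assay, and whether methoxy or trifluoromethyl would match compound 4.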